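The compounds below may be only part of what the source reports. "The series", "measured", "known", "first", "only" and "open" are said of these compounds alone.

In a functional assay on Raji cells (Homo sapiens) for antiproliferative activity, read by MTT assay, with a stated time of 48 h (on this read-out lower numbers stand for stronger inhibition and higher numbers for weaker inhibition), three compounds built on a shared core have been measured. Compound 1 `CN1CCN(CCn2c(N)c(-c3nc4ccccc4[nH]3)c3nc(C#N)c(C#N)nc32)CC1` gives > 50000 nM, which is a limit of the assay. Compound 2 `CCCn1c(N)c(-c2nc3ccccc3[nH]2)c2nc(C#N)c(C#N)nc21` likewise gives > 50000 nM, also a limit. Within the data shown here, compound 3 `CCN(CC)CCCn1c(N)c(-c2nc3ccccc3[nH]2)c2nc(C#N)c(C#N)nc21` gives 1870 nM, the only true number in the set. The next compound, compound 4 `CCN(CC)CCCCn1c(N)c(-c2nc3ccccc3[nH]2)c2nc(C#N)c(C#N)nc21`, has (diethylamino)methyl in place of diethylamino on a saturated chain carbon, three bonds along the chain from an aromatic nitrogen, which turns 3-(diethylamino)propyl into 4-(diethylamino)butyl ((diethylamino)methyl in place of diethylamino on a saturated chain carbon, three bonds along the chain from an aromatic nitrogen).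

Among the measured compounds shown here, two measured steps bear on this change. Diethylamino in place of hydrogen at that chain position gives an at least 26-fold lower number from compound 2 to compound 3 (1.42 log units; beyond the scatter), while the swap of the amine and chain of compound 1 gives an at least 26-fold lower number from compound 1 to compound 3 (1.42 log units; beyond the scatter). The remaining pair offers a step that the two limits leave unreadable from compound 1 to compound 2. These large steps show what separates compound 3 from the two limits, but none of them extends a chain while keeping the diethylamino group. No large shift is therefore expected in this assay, and no direction can be favoured with confidence. The expected size is a 1.1-fold higher number from compound 3 to compound 4 (0.03 log units; within the scatter). In this assay, compound 4 is estimated at 2000 nM, with an expected range from 600 nM to 8000 nM.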

Compound 4, half-maximal inhibitory concentration: 2640 nM
Beside the measured number, compound 4's estimate is 1.3-fold (0.12 log units) below it; measured number inside the range.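

In this assay the extra chain carbon that turns 3-(diethylamino)propyl into 4-(diethylamino)butyl gives a 1.4-fold higher number from compound 3 to compound 4 (0.15 log units; within the scatter) and so, on this one pair, a diethylamino group at the end of the chain stays in the measurable range at either length. The large separation from the plain propyl chain now holds for a second chain length, with an at least 18-fold lower number from compound 2 to compound 4 (1.27 log units; beyond the scatter) on that comparison, and the comparison with the 4-methylpiperazin-1-yl group on its shorter chain gives an at least 18-fold lower number from compound 1 to compound 4 (1.27 log units; beyond the scatter) as well. Both of these large steps start from a limit, so they are bounds and not sizes: (the limit of > 50000 nM in this assay, at which 2 of the 4 values shown sit).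

Compound 1 differs from compound 4 in both the amine and the chain length, so the compounds shown cannot tell whether the 4-methylpiperazin-1-yl group or the shorter chain accounts for its limit. Also open, going by these compounds, is how a 2-(diethylamino)ethyl or a 5-(diethylamino)pentyl chain would read, and whether a dimethylamino group or a morpholine ring in place of diethylamino would stay in the same range.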